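The compounds below may be only part of what the source reports. "The series", "measured", "known", "first", "only" and "open" are said of these compounds alone.

Of the compounds shown here, three sharing one core have been measured. Compound 1 `O=C(O)CCCCOc1ccc2c(=O)c(-c3ccc(O)cc3)coc2c1` gives 100 nM in an assay (Cricetulus griseus) for inhibition of aldehyde dehydrogenase, mitochondrial (Homo sapiens) (on this read-out lower numbers stand for stronger inhibition and higher numbers for weaker inhibition), compound 2 `CCOC(=O)COc1ccc2c(=O)c(-c3ccc(O)cc3)coc2c1` gives 130 nM, and compound 3 `O=c1c(-c2ccc(O)cc2)coc2cc(OCCCCCCCCCO)ccc12` gives 700 nM, the highest of the three numbers. Compound 4 `CCOC(=O)CCCCOc1ccc2c(=O)c(-c3ccc(O)cc3)coc2c1` differs from compound 3 by ethoxycarbonyl in place of 5-hydroxypentyl on a saturated chain carbon, four bonds along the chain from an oxygen on an aromatic ring. For the measured compounds named here, two measured steps bear on this change: exchanging the carboxy group for an ethyl ester gave a 1.3-fold higher number from compound 1 to compound 2 (0.11 log units; within the scatter), while exchanging the carboxy group for the hydroxypentyl chain gave a 7.0-fold higher number from compound 1 to compound 3 (0.85 log units; beyond the scatter), and a 5.4-fold higher number from compound 2 to compound 3 (0.73 log units; beyond the scatter) pointed the same way. Compound 4 removes that chain and carries the ester, so the expected step is a modest fall in number, a 5.4-fold lower number from compound 3 to compound 4 (0.73 log units; beyond the scatter). Compound 4 is therefore estimated at 130 nM, likely between 60 nM and 300 nM.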

Compound 4, half-maximal inhibitory concentration: 240 nM
Compound 4: middle estimate off by 1.8-fold (0.27 log units), on the low side; measured number inside the range.
By their numbers in this assay, from the lowest: compounds 1, 2 and 4 (each within the scatter of the next, the first and the last beyond it); then compound 3.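

For the compounds shown here, at the same chain length, the ethyl ester and the free acid can be compared directly for the first time, and capping the acid gives (a 2.4-fold higher number from compound 1 to compound 4 (0.38 log units; beyond the scatter)), a real but modest change. Among the ethyl esters, extending the chain to 3-(ethoxycarbonyl)propyl gives (a 1.8-fold higher number from compound 2 to compound 4 (0.27 log units; within the scatter)), so these two cannot be told apart, while replacing the hydroxyl-ended chain with this ester gives (a 2.9-fold lower number from compound 3 to compound 4 (0.46 log units; beyond the scatter)). No supporting data explain these differences. Going by these compounds, it remains open how an amide or an amine at the chain end would read, or a longer chain ending in a carboxylic acid.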